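Replacing the urea on the shared core: compound 3

This account rests on a few compounds, and the source may have more. Where it says the series, first, only, none or still open, it means among the compounds named here.

Measured so far:
compound 1 `CC(C)OC(=O)Nc1nc2ccc(NC(=O)c3c(Cl)cccc3Cl)cc2s1`, 0.0026 ug/mL
compound 2 `CCCCCCNC(=O)Nc1nc2ccc(NC(=O)c3c(Cl)cccc3Cl)cc2s1`, 0.29 ug/mL

Going by the values given here, in a functional assay on WI-38 VA13 cells (Homo sapiens) for cytotoxicity (a lower number here means that less compound is needed, a higher number that more compound is needed for the effect), compound 2 gives the highest of the two numbers; the only measured step, a 110-fold higher number from compound 1 to compound 2 (2.05 log units; beyond the scatter), is large and beyond the scatter. Compound 3 `COc1ccc(Nc2nc3ccc(NC(=O)c4c(Cl)cccc4Cl)cc3s2)cc1` differs from compound 2 by 4-methoxyphenyl in place of hexylcarbamoyl on a nitrogen on an aromatic ring. Among the compounds with values here, no measured step covers this change; the one known step alters the group on the carbonyl carbon and shows that this position tolerates large swings, so a wide range is allowed. Compound 3 is expected near 0.5 ug/mL, within 0.05 ug/mL to 5 ug/mL, an expected step of a 1.7-fold higher number from compound 2 to compound 3 (0.24 log units; within the scatter).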

Compound 3, half-maximal effective concentration: 0.87 ug/mL
Compound 3: the middle estimate sits 1.7-fold (0.24 log units) below what was measured; low and high end bracket the measured number.
By their numbers in this assay, from the lowest: compound 1; then compound 2; then compound 3.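

In this assay, a carbonyl on this nitrogen proves not to be required for a number in the range of compound 2: 4-methoxyphenyl in place of hexylcarbamoyl gives a 3.0-fold higher number from compound 2 to compound 3 (0.48 log units; beyond the scatter) and this step is modest. The same nitrogen with 4-methoxyphenyl in place of isopropoxycarbonyl gives a 330-fold higher number from compound 1 to compound 3 (2.52 log units; beyond the scatter) and this step is large, leaving isopropoxycarbonyl alone at the low end among the three groups. No measured evidence bears on the reason for this difference.

Still open, going by these compounds, is whether the low number depends on the isopropoxy group specifically or on any alkoxycarbonyl group. Methoxycarbonyl or tert-butoxycarbonyl on this nitrogen, or the free amine, would separate these readings.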